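This account rests on a few compounds, and the source may have more. Where it says the series, first, only, none or still open, it means among the compounds named here.

This account concerns two amides on a shared core, tested in a functional assay on MCF7 cells (Homo sapiens) for antiproliferative activity, read by MTT assay, with a stated time of 72 h (on this read-out higher numbers stand for weaker inhibition and lower numbers for stronger inhibition), and a third compound that awaits testing. Compound 1 `CCN(CC)CCNc1cc(C)c2cc(NC(=O)c3ccc(Cl)c(Cl)c3)ccc2n1` gives 1420 nM in this assay, the lowest of the two numbers recorded. Compound 2 `CCN1CCN(c2cc(C)c3cc(NC(=O)c4ccccc4C)ccc3n2)CC1` gives 10900 nM in this assay, a number higher than that of compound 1 by a margin beyond the scatter of repeated measurements. Within the data shown here, the two measured compounds do not differ in a single place, so no measured step is available as a guide.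

Compound 3 `CNc1cc(C)c2cc(NC(=O)c3ccc(Cl)c(Cl)c3)ccc2n1` has not yet been measured in this assay. It differs from compound 1 by one change: hydrogen in place of (diethylamino)methyl on a saturated chain carbon bound to a nitrogen on an aromatic ring. The (diethylamino)methyl group leaves and hydrogen enters on a saturated chain carbon bound to a nitrogen on an aromatic ring, so that (2-(diethylamino)ethyl)amino becomes methylamino. The expectation rests on compound 1 alone, whose value of 1420 nM in this assay sets the starting point. The expected step, a 3.5-fold higher number from compound 1 to compound 3 (0.55 log units; beyond the scatter), is thought to point toward weaker inhibition and to exceed the scatter, though with little certainty. Compound 3 is therefore estimated at 5000 nM in this assay, within a range from 1500 nM to 20000 nM.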

Compound 3, half-maximal inhibitory concentration: 2520 nM
Compound 3: middle estimate off by 2.0-fold (0.30 log units), on the high side, within the range that was stated.
By their numbers in this assay, from the lowest: compounds 1 and 3 (each within the scatter of the next); then compound 2.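

In this assay, exchanging (2-(diethylamino)ethyl)amino for methylamino on the shared core gives a 1.8-fold higher number from compound 1 to compound 3 (0.25 log units; within the scatter), so the two compounds cannot be told apart on this read-out. Among these compounds, this is the first measured step at this position, as the two earlier compounds differed in more than one place and offered no such comparison. It shows that, on this core and with this amide, the antiproliferative read-out does not depend measurably on keeping the (diethylamino)methyl group on the saturated chain carbon bound to a nitrogen on an aromatic ring, and nothing at hand offers an explanation for this result. The compounds shown leave open whether a plain amino group, or a longer chain such as 3-(diethylamino)propylamino, would also stay within the scatter of compound 1 at this position. They also leave open whether the same exchange would give a similarly small step on an amide carrying an unsubstituted benzoyl group rather than the dichlorinated ring shared by compound 1 and compound 3.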